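The source may report more compounds than this note shows. Statements on the series, on what has been measured and on what is new or still open speak of the compounds shown alone.

Measured compounds:
compound 1, `CC(C)[C@H](NC(=O)CN(c1ncnc2c1ncn2C1CCCCO1)C1CC1)C(=O)OCc1ccccc1`: 34.9%
compound 2, `CC(C)C[C@H](NC(=O)CN(c1nc(Cl)nc2[nH]cnc12)C1CC1)C(=O)OCc1ccccc1`: 27.3%
compound 3, `O=C(CN(c1nc(Cl)nc2[nH]cnc12)C1CC1)N[C@@H](CCC(=O)OCc1ccccc1)C(=O)OCc1ccccc1`: 53.7%

In a functional assay on the whole organism (Tail, strain ICR) with Mus musculus as the target, in the tail flick test, with a stated time of 60 min, at a dose of 25 umol/kg by the oral route (a lower number here means a weaker effect, a higher number a stronger effect of the compound at the dose given), compound 1 stands second highest of the three numbers: compound 2 sits within the scatter of it, while compound 3 lies beyond the scatter above it. The new compound 4, `C[C@H](NC(=O)CN(c1ncnc2c1ncn2C1CCCCO1)C1CC1)C(=O)OCc1ccccc1`, differs from compound 1 by one change: methyl in place of isopropyl on a saturated chain carbon bound to an amide-type nitrogen and a carbonyl carbon.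

Within the data shown here, only one measured step touches the same region of the molecule, the side chain carried by the amino-acid part: a number 26.4 percentage points higher from compound 2 to compound 3 (beyond the scatter). That step put a larger group in place of a smaller one at a related position and gave a modest rise. Compound 4 goes the other way, from a larger to a smaller group, so if that step is any guide, a drop or no change beyond the scatter is expected. With a single related step on a different core, confidence is low.

Compound 4 is therefore expected to give about 28%, roughly between 14% and 42%, an expected step of a number 6.9 percentage points lower from compound 1 to compound 4 (within the scatter).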

Compound 4, a percentage reported as activity, at one dose (the size of the read-out at that dose, not a potency): 53%
Estimate against measurement, compound 4: 25 percentage points below, and the stated range ends below it.
By their numbers in this assay, from the lowest: compounds 2 and 1 (each within the scatter of the next); then compounds 4 and 3 (each within the scatter of the next).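

In this assay, changing isopropyl to methyl on the saturated chain carbon bound to an amide-type nitrogen and a carbonyl carbon gives a number 18.1 percentage points higher from compound 1 to compound 4 (beyond the scatter), so with the rest of compound 1 kept, the smaller group does not cost effect at the dose given. The earlier step, a number 26.4 percentage points higher from compound 2 to compound 3 (beyond the scatter), also went up, but it brought in a larger group at a different place on the chain and on a different core, so the two steps give no simple rule that a larger or a smaller group is better. Nothing available here explains why the smaller group gives the higher number.

Still open, from the compounds shown here alone, is whether an ethyl group at this carbon, or a plain hydrogen atom, would keep the gain seen with methyl. The compounds shown also leave open whether the same swap would act in the same way on the core of compound 2.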